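The compounds below may be only part of what the source reports. "The series", "measured", "known", "first", "only" and "open" are said of these compounds alone.

Of the compounds shown here, three sharing one core have been tested in an ADME assay on HepG2 cells (Homo sapiens) for cytotoxicity, read by CellTiter-Glo and resazurin assay, with a stated time of 72 h; a higher number here means that more compound is needed for the effect, a lower number that less compound is needed. Compound 3, `CCOC(=O)CCCCCOc1cccc(CN(C(=O)c2ccc(-c3cccc(O)c3)cc2)C(C)C)c1`, carries a 3-hydroxyphenyl group, and in this assay compound 3 gives > 26000 nM, which is a limit of the assay rather than a number. Compound 1, `CCOC(=O)CCCCCOc1cccc(CN(C(=O)c2ccc(-c3cccc(N(C)C)c3)cc2)C(C)C)c1`, gives > 26000 nM in this assay, again a limit. Compound 2, `CCOC(=O)CCCCCOc1cccc(CN(C(=O)c2ccc(-c3ccco3)cc2)C(C)C)c1`, gives > 26000 nM in this assay, also a limit. Compound 3 therefore stands where every measured value stands: the limit of > 26000 nM in this assay, at which 3 of the 3 values shown sit. The steps that lead into compound 3, a step that the two limits leave unreadable from compound 1 to compound 3 and a step that the two limits leave unreadable from compound 2 to compound 3, cannot be sized for this reason.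

Compound 4, `CCOC(=O)CCCCCOc1cccc(CN(C(=O)c2ccc(-c3cc(F)cc(OC)c3)cc2)C(C)C)c1`, is not yet measured. Its difference from compound 3 is 3-fluoro-5-methoxyphenyl in place of 3-hydroxyphenyl on an aromatic carbon. Within the data shown here, because all three values shown sit at the limit (the limit of > 26000 nM in this assay, at which 3 of the 3 values shown sit), no measured step shows what a change at this position does in this assay, and no direction can be read from them. The expectation is that compound 4 behaves like its neighbours and that the step that the limit leaves unreadable from compound 3 to compound 4 stays within the scatter. Compound 4 is thus estimated at 30000 nM, with a range from 15000 nM to 80000 nM, most likely reported again as a limit.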

Compound 4, half-maximal effective concentration: > 26000 nM
Compound 4 ended at the assay's limit; the forecaster's own chance of this, stated with the estimate: 85%; the middle value lies beyond the limit too.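

The steps from compound 1, compound 2 and compound 3 to compound 4 cannot be read in this assay, as all four compounds sit at one limit: the limit of > 26000 nM in this assay, at which 4 of the 4 values shown sit.

The compounds shown leave open at what concentration, if any, each of the four affects these cells.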